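A few compounds are considered here, and "the series" means these few. Any claim that something is new, unique, unknown or untested is made for them only; others in the source may bear on it.

Measured in a functional assay on A549 cells (Homo sapiens) for cytotoxicity, read by MTT assay, with a stated time of 72 h; on this read-out higher numbers stand for weaker inhibition and lower numbers for stronger inhibition:

Compound 1 `CN(C)CCn1cnnc1-c1cc(Oc2ccc(NC(=O)N/N=C/c3cccc(Cl)c3Cl)cc2F)ccn1` gives 1090 nM
Compound 2 `CN(C)CCn1cnnc1-c1cc(Oc2ccc(NC(=O)N/N=C/c3ccc(Cl)cc3)cc2F)ccn1` gives 780 nM

Within the data shown here, compound 2 sits together with compound 1, since the only step, a 1.4-fold lower number from compound 1 to compound 2 (0.15 log units; within the scatter), lies within the scatter and the two numbers cannot be ranked against each other. Compound 3 `COc1ccc(/C=N/NC(=O)Nc2ccc(Oc3ccnc(-c4nncn4CCN(C)C)c3)c(F)c2)cc1O` differs from compound 2 by 3-hydroxy-4-methoxyphenyl in place of 4-chlorophenyl on a carbon with a double bond to nitrogen. Among the measured compounds shown here, no measured step covers a change of this kind; the single step of a 1.4-fold lower number from compound 1 to compound 2 (0.15 log units; within the scatter) concerns only a chlorine pattern and was small. The step of a 1.9-fold higher number from compound 2 to compound 3 (0.28 log units; within the scatter) is therefore expected to be modest, with a wide range. Compound 3 is expected to give about 1500 nM in this assay, between 500 nM and 5000 nM.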

Compound 3, half-maximal inhibitory concentration: > 100000 nM
Compound 3 was reported as a limit; the forecaster's own chance of this, stated with the estimate: 10%; at least 66-fold (1.82 log units) between middle value and limit.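

At this position, on a carbon with a double bond to nitrogen, the two chlorinated phenyl groups could not be ranked, yet 3-hydroxy-4-methoxyphenyl brings a large loss of activity against either of them (an at least 120-fold higher number from compound 2 to compound 3 (2.10 log units; beyond the scatter); an at least 91-fold higher number from compound 1 to compound 3 (1.96 log units; beyond the scatter)). The aryl group here therefore can matter greatly, which the first pair did not reveal. The entry for compound 3 is a limit and not a number: the limit of > 100000 nM in this assay, at which 1 of the 3 values shown sits. The compounds shown leave open whether the hydroxy group, the methoxy group or the two together carry this step. From the compounds shown here alone, how an amine or a carboxylic acid on this phenyl ring would read also remains open.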